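The compounds below may be only part of what the source reports. "The series", "measured", "known", "first", "only" and "open" are said of these compounds alone.

Measured compounds:
- compound 1 `CC1=C(C(=O)OC(C)(C)C)C(c2cccs2)NC(=S)N1`: in an assay on membranes from HeLa cells for displacement of a labelled ligand from adenosine receptor A3 (Homo sapiens), read by scintillation counting, with a stated time of 180 min, tested at 1 uM (a lower number here means less inhibition, a higher number more inhibition at the concentration tested (going by the name of the read-out)), compound 1 gives 22%
- compound 2 `CC1=C(C(N)=O)C(c2ccoc2)NC(=O)N1`: in this assay compound 2 gives 2%
- compound 3 `CC1=C(C(N)=O)C(c2ccsc2)NC(=O)N1`: in this assay compound 3 gives 1%

Compound 2 stands second highest of the three numbers, its nearest neighbour being compound 3, which lies within the scatter of it; compound 1 lies beyond the scatter, higher. For the measured compounds named here, the only single-point step measured is a number 1 percentage points lower from compound 2 to compound 3 (within the scatter), a change of the aromatic ring on a saturated ring carbon, and it stays within the scatter.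

Compound 4 `CC1=C(C(=O)OC2CCCC2)C(c2ccoc2)NC(=O)N1` differs from compound 2 by cyclopentyloxy in place of amino on a carbonyl carbon. Going by the values given here, no measured step changes the group on the carbonyl carbon by itself; compound 1, which carries an ester there, differs from compound 2 in several places at once, so its two values show only that an ester-bearing member of the series reached a higher number. Among the compounds with values here, the step to compound 4 therefore has no direct precedent in the data, and the expectation rests on compound 1 alone. For compound 4 the estimated step is a number 8 percentage points higher from compound 2 to compound 4 (within the scatter), expected to be upward but modest. The expected value for compound 4 in this assay is 10%, ranging from 0% to 28%.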

Compound 4, a percentage reported as inhibition, at one concentration (the size of the read-out at that concentration, not a potency): 1%
For compound 4 the middle estimate is 9 percentage points above the measured one; low and high end bracket the measured number.
By their numbers in this assay, from the lowest: compounds 3, 4 and 2 (each within the scatter of the next); then compound 1.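

In this assay the carbonyl carbon now has a measured single-place change, cyclopentyloxy in place of amino: a number 1 percentage points lower from compound 2 to compound 4 (within the scatter). Losing the amino group with its hydrogen-bond donor and bringing in a five-membered carbon ring therefore leaves the number within the scatter, on the background of compound 2. For the compounds shown here, this position now reads like the saturated ring carbon carrying the aromatic ring, where the only measured step is also within the scatter: a number 1 percentage points lower from compound 2 to compound 3 (within the scatter). No measurement on hand explains this absence of a shift.

On these data alone, compound 1 gives 22% but differs from the others in several places, so which of those places matters stays open. Also open, as far as these compounds go, is whether a carboxylic acid or a dimethylamino group on the carbonyl carbon would read differently from amino and cyclopentyloxy.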